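Hydroxypropyl chain on the fluorobenzyl core

A few compounds are considered here, and "the series" means these few. Any claim that something is new, unique, unknown or untested is made for them only; others in the source may bear on it.

Compound 3 `CCCCCCNc1nc(-c2ccccc2)nc2c1nnn2Cc1ccccc1F` is level with compound 2 `CNc1nc(-c2ccccc2)nc2c1nnn2Cc1ccccc1F` at the digits shown, and the two sit together at the lowest of the three numbers in an assay on isolated protein for binding affinity to adenosine receptor A1 (Bos taurus); a lower number here means a stronger inhibitor, a higher number a weaker inhibitor: compound 3 gives 25000000 nM, compound 2 gives 25000000 nM, and compound 1 `OCCCNc1nc(-c2ccccc2)nc2c1nnn2Cc1ccccc1Cl` gives 33000000 nM, a gap from compound 3 that lies within the scatter. The change to compound 4 `OCCCNc1nc(-c2ccccc2)nc2c1nnn2Cc1ccccc1F` is hydroxy in place of propyl on a saturated chain carbon, three bonds along the chain from a nitrogen on an aromatic ring. For the measured compounds named here, the one comparable step, no change at the digits printed from compound 2 to compound 3 (within the scatter), moved nothing, so chain length on that nitrogen has not mattered in this assay. Compound 1 already carries the same hydroxypropyl chain on a chlorobenzyl variant and sits within the scatter of compound 3. Compound 4 is therefore expected at 30000000 nM (range 12000000 nM to 80000000 nM), a step of a 1.2-fold higher number from compound 3 to compound 4 (0.08 log units; within the scatter) that is expected to stay inside the scatter.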

Compound 4, inhibition constant: 3700000 nM
Estimate against measurement, compound 4: 8.1-fold (0.91 log units) above, and the stated range ends above it.
By their numbers in this assay, from the lowest: compound 4; then compounds 2, 3 and 1 (each within the scatter of the next).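

In this assay hydroxy in place of propyl gives a 6.8-fold lower number from compound 3 to compound 4 (0.83 log units; beyond the scatter) and 2-hydroxyethyl in place of hydrogen gives a 6.8-fold lower number from compound 2 to compound 4 (0.83 log units; beyond the scatter) while the chain change alone gave no change at the digits printed from compound 2 to compound 3 (within the scatter) so the hydroxy on the chain, not chain length, goes with the lower number. Fluoro in place of chloro on an aromatic carbon gives an 8.9-fold lower number from compound 1 to compound 4 (0.95 log units; beyond the scatter) so the 3-hydroxypropyl chain alone does not set the number. Still open, going by these compounds, is whether an amine, a methoxy or a carboxylic acid in place of the hydroxy, or a longer hydroxyalkyl chain, would behave alike. No available evidence accounts for these steps.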